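This account rests on a few compounds, and the source may have more. Where it says the series, first, only, none or still open, it means among the compounds named here.

In a functional assay on PC-3 cells (Homo sapiens) for cytotoxicity, read by MTT assay, with a stated time of 72 h (on this read-out lower numbers stand for stronger inhibition and higher numbers for weaker inhibition), compound 3 `Cc1cc(=O)n(-c2ccccc2OC(F)(F)F)nc1C(=O)Nc1ccc(Oc2ncnc3c2ccn3C)cc1` gives 5160 nM, the lowest of the numbers shown. Going by the values given here, compound 2 `Cc1cc(=O)n(-c2ccccc2OC(F)(F)F)nc1C(=O)Nc1ccc(Oc2ncnc3[nH]ccc23)cc1` gives 22500 nM in this assay, and the only single change measured is a 4.4-fold lower number from compound 2 to compound 3 (0.64 log units; beyond the scatter). Compound 1 `COc1ccc(-n2ccc(=O)c(C(=O)Nc3ccc(Oc4ccnc5c4ccn5C)cc3)n2)cc1` reaches only the limit of this assay, > 60000 nM. Compound 4 `Cc1cc(=O)n(-c2cccc(F)c2)nc1C(=O)Nc1ccc(Oc2ncnc3c2ccn3C)cc1` differs from compound 3 by 3-fluorophenyl in place of 2-(trifluoromethoxy)phenyl on an aromatic nitrogen. Among the compounds with values here, none of the measured steps alters the group on this aromatic nitrogen; the one measured step concerns a methyl on a different aromatic nitrogen, so it offers no direct guide to this exchange. The expected step is therefore within the scatter, a 1.0-fold lower number from compound 3 to compound 4 (0.01 log units; within the scatter). In this assay compound 4 is estimated at 5000 nM, with a range from 1500 nM to 20000 nM.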

Compound 4, half-maximal inhibitory concentration: > 60000 nM
Compound 4: only a limit was reported; the forecaster's own chance of this, stated with the estimate: 10%; at least 12-fold (1.07 log units) between middle value and limit.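

In this assay, going by these compounds alone, the group on this aromatic nitrogen proves decisive, which the earlier compounds could not show, as none of their measured steps altered it: 3-fluorophenyl in place of 2-(trifluoromethoxy)phenyl gives an at least 11-fold higher number from compound 3 to compound 4 (1.06 log units; beyond the scatter). Compound 4 gives only a limit and not a number, so the step has no upper end, and this limit recurs among the compounds shown: the limit of > 60000 nM in this assay, at which 2 of the 4 values shown sit.

A single exchange cannot separate losing the trifluoromethoxy group from gaining the fluorine. Going by these compounds, how a plain phenyl or a benzyl group would behave on this nitrogen remains open.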